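Naphthalen-1-yl replaces the halogenated phenyl on the ring nitrogen

The compounds below may be only part of what the source reports. "The series", "measured", "known", "first", "only" and "open" are said of these compounds alone.

Compound 1 `Nc1scc(CN2CCN(c3ccc(F)cc3Cl)CC2)c1C(=O)c1ccc(Cl)cc1` was tested in an assay on CHO cells for displacement of a labelled ligand from adenosine receptor A1 (Homo sapiens), read by scintillation counting, with a stated time of 120 min, tested at 10 uM (on this read-out lower numbers stand for less inhibition and higher numbers for more inhibition at the one concentration tested (going by the name of the read-out)), where compound 1 gives 0%. Compound 2 `COc1ccc(N2CCN(Cc3csc(N)c3C(=O)c3ccc(Cl)cc3)CC2)cc1` carries 4-methoxyphenyl in place of 2-chloro-4-fluorophenyl on an amine nitrogen in a ring, and in this assay compound 2 gives 0%. The step of no change at the digits printed from compound 1 to compound 2 (within the scatter) shows that swapping the aryl group on that nitrogen left the read-out where it was, so compound 1 stands level with compound 2 at the floor of the measurement. Compound 3 `Nc1scc(CN2CCN(c3cccc4ccccc34)CC2)c1C(=O)c1ccc(Cl)cc1` differs from compound 1 in one place: naphthalen-1-yl in place of 2-chloro-4-fluorophenyl on an amine nitrogen in a ring. Among the measured compounds shown here, the only measured step that bears on this change, no change at the digits printed from compound 1 to compound 2 (within the scatter), was flat, so the expected step of a number 5 percentage points higher from compound 1 to compound 3 (within the scatter) is none beyond the scatter. Compound 3 is therefore estimated to give 5% in this assay, with a range from 0% to 25%.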

Compound 3, a percentage reported as inhibition, at one concentration (the size of the read-out at that concentration, not a potency): 1%
The estimate for compound 3 lay 4 percentage points above the measured number, within the range that was stated.
By their numbers in this assay, from the lowest: compounds 1, 2 and 3 (each within the scatter of the next).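

In this assay, naphthalen-1-yl on the amine nitrogen in a ring gave a number 1 percentage points higher from compound 1 to compound 3 (within the scatter), and set against 4-methoxyphenyl it gave a number 1 percentage points higher from compound 2 to compound 3 (within the scatter). The earlier pair held only single-ring aryl groups at this position, whereas all three compounds now lie within the scatter of one another, including one with 2 six-membered aromatic rings of carbon only and no halogen. No measurement at hand offers an account of this flat result.

The compounds shown leave open whether anything other than an aromatic ring on that nitrogen, such as a benzyl group, an acyl group or a longer chain ending in a carboxylic acid, would move the read-out. They also leave open whether any group at this position can do so while the rest of the shared core stays unchanged.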